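The source may report more compounds than this note shows. Statements on the series, on what has been measured and on what is new or still open speak of the compounds shown alone.

The shared core is carried by three measured compounds. Compound 1 `C#CCSc1nc(NCCC(C)C)c2ccncc2n1` is tested in a functional assay on MGC-803 cells (Homo sapiens) for inhibition, read by MTT assay, with a stated time of 72 h; on this read-out higher numbers stand for weaker inhibition and lower numbers for stronger inhibition. For compound 1 the result is a limit of the assay, not a number: > 80000 nM, as noted in the limit of > 80000 nM in this assay, at which 1 of the 3 values shown sits. Compound 2 `C#CCSc1nc(Nc2ccc(Br)cc2)c2ccncc2n1` gives 26000 nM in this assay, and compound 3 `C#CCSc1nc(Nc2ccccc2OC)c2ccncc2n1` gives 3440 nM. Among the compounds with values here, the one step between compounds that differ in a single place is an at least 3.0-fold lower number from compound 1 to compound 2 (0.48 log units; beyond the scatter). Compound 3 stands at the lowest of the two numbers shown; the nearest measured neighbour is compound 2, whose number is higher, and the third value is a limit.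

Compound 4 `C#CCSc1nc(Nc2ccccc2O)c2ccncc2n1` is not yet measured. It differs from compound 3 by hydrogen in place of methyl on an oxygen on an aromatic ring, read one bond further out as methoxy to hydroxy. Within the data shown here, no measured step touches this oxygen: the only step measured, from compound 1 to compound 2, alters the substituent on the ring nitrogen, so nothing in the set says how large a change at this oxygen should be. The expectation is therefore a step from compound 3 to compound 4 of a 1.5-fold higher number from compound 3 to compound 4 (0.16 log units; within the scatter) in this assay, with no firm direction. For compound 4 the estimated value is 5000 nM, expected to lie between 1500 nM and 20000 nM.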

Compound 4, half-maximal inhibitory concentration: 21000 nM
Beside the measured number, compound 4's estimate is 4.2-fold (0.62 log units) below it, and the stated range ends below it.
By their numbers in this assay, from the lowest: compound 3; then compounds 4 and 2 (each within the scatter of the next). At a limit, above all of these: compound 1.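

The change from methoxy to hydroxy, which removes one carbon, gives a 6.1-fold higher number from compound 3 to compound 4 (0.79 log units; beyond the scatter) in this assay, so this oxygen on the aromatic ring is a place where a small change registers beyond the scatter, something the earlier step, confined to the group on the ring nitrogen, could not show. The methyl on that oxygen also counts for more than the mere presence of an oxygen there: with hydroxy in its place, the exchange of 4-bromophenyl for 2-hydroxyphenyl gives a 1.2-fold lower number from compound 2 to compound 4 (0.09 log units; within the scatter), which leaves these two aryl groups unseparated. Even so, 2-hydroxyphenyl in place of isopentyl still gives an at least 3.8-fold lower number from compound 1 to compound 4 (0.58 log units; beyond the scatter), a step that can be read only in one direction, since the figure for compound 1 is a limit of the assay: the limit of > 80000 nM in this assay, at which 1 of the 4 values shown sits.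

The compounds shown offer no measurement that accounts for the step at this oxygen. Still open, as far as these compounds go, is how an ethyl group or a longer chain on this oxygen, or an amine in place of the hydroxy, would read in this assay, and whether a methoxy group would give a similar step on the 4-bromophenyl ring.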